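Chain length between the bromine and the aryl ether oxygen

A few compounds are considered here, and "the series" means these few. Any claim that something is new, unique, unknown or untested is made for them only; others in the source may bear on it.

Three compounds on a shared core have numbers in a functional assay on U-937 cells (Homo sapiens) for cytotoxicity, read by MTT assay, with a stated time of 24 h; on this read-out higher numbers stand for weaker inhibition and lower numbers for stronger inhibition. Compound 1 `BrCCCCCCOc1c(Br)cc(Br)cc1Oc1ccc(Br)cc1Br` gives 33.8 ug/mL, compound 2 `CN1CCN(CCCCCOc2c(Br)cc(Br)cc2Oc2ccc(Br)cc2Br)CC1` gives 49.1 ug/mL, and compound 3 `BrCCOc1c(Br)cc(Br)cc1Oc1ccc(Br)cc1Br` gives 32.5 ug/mL. Compound 3 carries the smallest of the three numbers, yet the gaps to its neighbours are small: the step of a 1.0-fold lower number from compound 1 to compound 3 (0.02 log units; within the scatter) and the step of a 1.5-fold lower number from compound 2 to compound 3 (0.18 log units; within the scatter) both fall within the scatter, so the three are not separated. Compound 4 `BrCCCCOc1c(Br)cc(Br)cc1Oc1ccc(Br)cc1Br` is not yet measured. It differs from compound 3 by 2-bromoethyl in place of bromo on a saturated chain carbon, two bonds along the chain from an oxygen on an aromatic ring. Within the data shown here, the step that bears most directly on this is the one from compound 1 to compound 3, where a shortening of the same chain gave a 1.0-fold lower number from compound 1 to compound 3 (0.02 log units; within the scatter); the step of a 1.5-fold higher number from compound 1 to compound 2 (0.16 log units; within the scatter) also changed only the chain end and likewise stayed within the scatter. An intermediate chain is therefore expected to leave this assay essentially unchanged, and the step of a 1.0-fold higher number from compound 3 to compound 4 (0.01 log units; within the scatter) is estimated to stay within the scatter. Compound 4 is expected to give 33 ug/mL, between 20 ug/mL and 55 ug/mL.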

Compound 4, half-maximal inhibitory concentration: 29 ug/mL
Compound 4: the middle estimate sits 1.1-fold (0.06 log units) above what was measured; the measured number falls inside the stated range.
By their numbers in this assay, from the lowest: compounds 4, 3, 1 and 2 (each within the scatter of the next).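

Placing 2-bromoethyl in place of bromo, on a saturated chain carbon two bonds along the chain from an oxygen on an aromatic ring, gives a chain of intermediate length, and in this assay this step (a 1.1-fold lower number from compound 3 to compound 4 (0.05 log units; within the scatter)) stays within the scatter, as does the step to the longest bromo-ended chain (a 1.2-fold lower number from compound 1 to compound 4 (0.07 log units; within the scatter)). Among these compounds, the three bromo-ended chains therefore show no dependence on chain length, and the step from the 4-methylpiperazin-1-yl compound (a 1.7-fold lower number from compound 2 to compound 4 (0.23 log units; within the scatter)) is also within the scatter, so no compound is separated from the others. Nothing available accounts for this flat result.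

The compounds shown leave open whether a longer chain would separate from this group. They also leave open whether a carboxylic acid or a primary amine at the chain end would do so.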